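The source may report more compounds than this note shows. Statements on the series, on what has been measured and on what is new or still open speak of the compounds shown alone.

For the measured compounds named here, compound 2 `CCCN(CC[C@H]1CC[C@H](NC(=O)c2ccccc2-n2cccn2)CC1)[C@H]1CCc2nc(N)sc2C1` gives 2 nM in an assay on brain for displacement of a labelled ligand from D(3) dopamine receptor (Rattus norvegicus) (on this read-out higher numbers stand for weaker inhibition and lower numbers for stronger inhibition), the lowest of the two numbers so far. Compound 1 `CCCN(CC[C@H]1CC[C@H](NC(=O)/C=C/c2ccccc2OC)CC1)[C@H]1CCc2nc(N)sc2C1` gives 8.1 nM, so that there is a 4.1-fold lower number from compound 1 to compound 2 (0.61 log units; beyond the scatter). Compound 3 `CCCN(CC[C@H]1CC[C@H](NC(=O)c2ccc(-n3ccnc3)cc2)CC1)[C@H]1CCc2nc(N)sc2C1` is to be measured in this assay; it differs from compound 2 by 4-(1H-imidazol-1-yl)phenyl in place of 2-(1H-pyrazol-1-yl)phenyl on a carbonyl carbon. Going by the values given here, only the step from compound 1 to compound 2 touches the same carbonyl carbon, and it exchanged a quite different group, so it bears on this change only loosely; a small step, if any beyond the scatter, is expected for compound 3. Compound 3 is therefore estimated at 5 nM, between 1.5 nM and 20 nM, which would mean a 2.5-fold higher number from compound 2 to compound 3 (0.40 log units; beyond the scatter).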

Compound 3, inhibition constant: 1.9 nM
For compound 3 the middle estimate is 2.6-fold (0.42 log units) above the measured one; measured number inside the range.
By their numbers in this assay, from the lowest: compounds 3 and 2 (each within the scatter of the next); then compound 1.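

In this assay, exchanging 2-(1H-pyrazol-1-yl)phenyl for 4-(1H-imidazol-1-yl)phenyl on the carbonyl carbon gives a 1.1-fold lower number from compound 2 to compound 3 (0.02 log units; within the scatter), so this position accepts two differently joined groups of the same atoms without a readable change. The gain over 2-(2-methoxyphenyl)ethenyl also holds for the new group, with a 4.3-fold lower number from compound 1 to compound 3 (0.63 log units; beyond the scatter). No measurement available here explains the result.

This change alters the five-membered ring and its attachment together, and the two effects cannot be separated. As far as these compounds go, how a carboxylic acid or an aliphatic amine on the phenyl ring would read remains open.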